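This account rests on a few compounds, and the source may have more. Where it says the series, first, only, none or still open, it means among the compounds named here.

Compounds measured in an assay on CHO cells for binding affinity to metabotropic glutamate receptor 2 (Rattus norvegicus); on this read-out higher numbers stand for weaker inhibition and lower numbers for stronger inhibition:
compound 1, `CO[C@@H]1C[C@@H]2[C@H]([C@]1(N)C(=O)O)[C@@]2(F)C(=O)O`: 39.2 nM
compound 2, `N[C@]1(C(=O)O)[C@H]2[C@@H](C[C@H]1OCc1ccccc1)[C@]2(F)C(=O)O`: 7.14 nM
compound 3, `N[C@]1(C(=O)O)[C@H]2[C@@H](C[C@H]1OCCCc1ccccc1)[C@]2(F)C(=O)O`: 9.83 nM

Compound 2 stands at the lowest number of the three in this assay. Its nearest neighbour is compound 3, with a 1.4-fold higher number from compound 2 to compound 3 (0.14 log units; within the scatter), so no order can be read between those two; its furthest is compound 1, with a 5.5-fold lower number from compound 1 to compound 2 (0.74 log units; beyond the scatter).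

Compound 4, `N[C@]1(C(=O)O)[C@H]2[C@@H](C[C@H]1OCc1cccc(C(F)(F)F)c1)[C@]2(F)C(=O)O`, differs from compound 2 by trifluoromethyl in place of hydrogen on an aromatic carbon. Among the measured compounds shown here, no measured step alters a substituent on the aromatic ring itself. The steps that bear at all are those that introduced the aryl-bearing chain: a 5.5-fold lower number from compound 1 to compound 2 (0.74 log units; beyond the scatter) and a 4.0-fold lower number from compound 1 to compound 3 (0.60 log units; beyond the scatter), both modest, and the chain-length change a 1.4-fold higher number from compound 2 to compound 3 (0.14 log units; within the scatter), which lies within the scatter. They speak to the presence of the aromatic ring, not to groups on it, so no direction can be drawn from them. The step of a 1.1-fold higher number from compound 2 to compound 4 (0.02 log units; within the scatter) is therefore expected to stay within the scatter, with wide uncertainty. Compound 4 is expected to give about 7.5 nM in this assay, in the range 2.5 nM to 22 nM.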

Compound 4, inhibition constant: 5.72 nM
Beside the measured number, compound 4's estimate is 1.3-fold (0.12 log units) above it; measured number inside the range.
By their numbers in this assay, from the lowest: compounds 4, 2 and 3 (each within the scatter of the next); then compound 1.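

In this assay, trifluoromethyl in place of hydrogen on an aromatic carbon gives a 1.2-fold lower number from compound 2 to compound 4 (0.10 log units; within the scatter), so this first change on the aromatic ring itself does not move the number outside the scatter. Among the compounds shown here, the result shows that this aromatic carbon, meta to a large group, can carry a group of 4 heavy atoms with no measurable change in binding affinity on this read-out, whereas the earlier steps concerned only the chain bearing the ring. Nothing at hand accounts for this outcome.

Going by these compounds, whether the same carbon would accept a different group, such as an amine, a carboxylic acid or a nitrile, remains open. Also open, on these data alone, is whether trifluoromethyl on another carbon of the ring, or on the longer phenethyl chain of compound 3, would leave the number equally unchanged.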